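Compound 2 to compound 3: methyl in place of hydrogen

This account rests on a few compounds, and the source may have more. Where it says the series, first, only, none or still open, it means among the compounds named here.

Measured so far in a physicochemical assay for lipophilicity; on this read-out lower numbers stand for lower lipophilicity and higher numbers for higher lipophilicity:
Compound 1 `CCCCOC(=O)c1ccc(S(N)(=O)=O)cc1`: 2.34
Compound 2 `CCCCCOC(=O)c1ccc(S(N)(=O)=O)cc1`: 2.71

Of the two numbers in this assay, the higher belongs to compound 2, at 2.71. Compound 3 `CCCCCCOC(=O)c1ccc(S(N)(=O)=O)cc1` differs from it by methyl in place of hydrogen on a saturated chain carbon, five bonds along the chain from an oxygen next to a carbonyl group, with methyl in place of hydrogen on a saturated chain carbon, five bonds along the chain from an oxygen next to a carbonyl group. Among the compounds with values here, only one measured step bears on this: a number 0.37 log units higher from compound 1 to compound 2 (beyond the scatter), the same replacement made four bonds along the chain. An upward step of similar size is therefore expected, estimated as a number 0.39 log units higher from compound 2 to compound 3 (beyond the scatter). For compound 3 the estimated value is 3.1, with an expected range of 2.88 to 3.32.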

Compound 3, partition coefficient: 3.23
The estimate for compound 3 lay 0.13 log units below the measured number, within the range that was stated.
By their numbers in this assay, from the lowest: compound 1; then compound 2; then compound 3.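

In this assay, methyl in place of hydrogen raises the number again when made five bonds along the chain from an oxygen next to a carbonyl group, with a number 0.52 log units higher from compound 2 to compound 3 (beyond the scatter) in the same direction as the step made four bonds along. Read as one change, ethyl in place of hydrogen four bonds along the chain gives a number 0.89 log units higher from compound 1 to compound 3 (beyond the scatter) for the two added carbons together. Nothing available here accounts for these steps. Going by these compounds, whether a longer chain continues the rise stays open, and so does what an amine or a carboxylic acid in place of the methyl gives in this assay.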